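The source may hold more compounds than are shown below. What is called first, only, known or untested is meant among the compounds shown, and "the series" means these compounds.

Measured compounds:
- Compound 1, `O/N=C(/CCN1CCN(c2ccccn2)CC1)c1ccccc1Cl`, gives 64% in a functional assay on HEK293 cells with D(4) dopamine receptor (Homo sapiens) as the target, read by FLIPR; on this read-out lower numbers stand for smaller maximal responses and higher numbers for larger maximal responses.
- Compound 2, `Cc1ccccc1/C(CCN1CCN(c2ccccn2)CC1)=N\O`, gives 72%.
- Compound 3, `O/N=C(\CCN1CCN(c2ccccn2)CC1)c1cc(F)cc(F)c1`, gives 74%.

Compound 3 stands within the usual scatter of both compound 2 and compound 1 on these numbers, so the three cannot be ranked. Compound 4, `O/N=C(/CCN1CCN(c2ccccn2)CC1)c1cc(F)cc(F)c1`, is not yet measured. Its difference from compound 3 is the two compounds have the same atoms and bonds and differ only in configuration as drawn: 1 of 1 stereo elements differ; a double bond is drawn E in compound 3 and Z in compound 4. For the measured compounds named here, the one measured step, a number 8 percentage points higher from compound 1 to compound 2 (within the scatter), concerns a group swap on an aromatic carbon, not drawn geometry, so it bears only loosely on this change; no measured pair here differs in the geometry of the double bond. The expected step is therefore a number 2 percentage points lower from compound 3 to compound 4 (within the scatter), none beyond the scatter. Compound 4 is estimated at 72%, with a range from 55% to 85%.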

Compound 4, largest response reached (reported as efficacy), in percent of the reference or control that the assay uses: 70%
Estimate against measurement, compound 4: 2 percentage points above, and the stated range covers the measured number.
By their numbers in this assay, from the lowest: compounds 1, 4, 2 and 3 (each within the scatter of the next).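

In this assay, for the compounds shown here, redrawing the double bond from E to Z gives a number 4 percentage points lower from compound 3 to compound 4 (within the scatter), the first measured change in geometry alone. That reading rests on one point: the fact that compounds 3 and 4 differ only in the configuration as drawn. Among the ring changes, 3,5-difluorophenyl in place of 2-methylphenyl gives a number 2 percentage points lower from compound 2 to compound 4 (within the scatter), and 3,5-difluorophenyl in place of 2-chlorophenyl gives a number 6 percentage points higher from compound 1 to compound 4 (within the scatter), so no step here leaves the scatter.

Going by these compounds, whether geometry matters as little with 2-chlorophenyl or 2-methylphenyl on that carbon remains open. So does whether a methoxy group in place of the hydroxyl would shift the response.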